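Aryl swap on the shared core: compound 3 to compound 4

The source may report more compounds than this note shows. Statements on the series, on what has been measured and on what is new or still open speak of the compounds shown alone.

Measured so far in a functional assay on THP-1 cells (Homo sapiens) for inhibition, read by ELISA, with stated times of 1 h and 18 h; on this read-out higher numbers stand for weaker inhibition and lower numbers for stronger inhibition
- compound 1 `NC(=O)[C@@H]1[C@H](Nc2nc(Nc3cccc(C(=O)N4CCCC4)c3)ncc2-c2ccccc2)[C@H]2C=C[C@@H]1C2` gives 220 nM
- compound 2 `NC(=O)[C@@H]1[C@H](Nc2nc(Nc3cccc(C(=O)N4CCCC4)c3)ncc2-c2ccc(F)cc2)[C@H]2C=C[C@@H]1C2` gives 460 nM
- compound 3 `NC(=O)[C@@H]1[C@H](Nc2nc(Nc3cccc(C(=O)N4CCCC4)c3)ncc2-c2cncc(F)c2)[C@H]2C=C[C@@H]1C2` gives 170 nM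

The step of a 1.3-fold lower number from compound 1 to compound 3 (0.11 log units; within the scatter) stays within the scatter, so compound 3 at 170 nM has the lowest number of the set but cannot be separated from compound 1. It does stand clear of compound 2, as the step of a 2.7-fold lower number from compound 2 to compound 3 (0.43 log units; beyond the scatter) shows.

The next structure is compound 4 `N#Cc1cccc(-c2cnc(Nc3cccc(C(=O)N4CCCC4)c3)nc2N[C@H]2[C@@H](C(N)=O)[C@@H]3C=C[C@H]2C3)c1`, which carries 3-cyanophenyl in place of 5-fluoropyridin-3-yl on an aromatic carbon.

Going by the values given here, all the measured steps bear on this change, since each swaps the aryl group on that same aromatic carbon. They are small, with the step of a 2.1-fold higher number from compound 1 to compound 2 (0.32 log units; beyond the scatter) and the step of a 2.7-fold lower number from compound 2 to compound 3 (0.43 log units; beyond the scatter) both modest. Among the compounds with values here, no measured compound carries a nitrile, so that feature is untested here. On these data alone, a step beyond the scatter in this assay is therefore not expected, and the direction stays open. The expected step is a 1.2-fold higher number from compound 3 to compound 4 (0.07 log units; within the scatter) on this evidence. For compound 4 the estimated value is 200 nM, with an expected range of 80 nM to 500 nM.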

Compound 4, half-maximal inhibitory concentration: 280 nM
Compound 4: middle estimate off by 1.4-fold (0.15 log units), on the low side, and the stated range covers the measured number.
By their numbers in this assay, from the lowest: compounds 3, 1, 4 and 2 (each within the scatter of the next, the first and the last beyond it).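

In this assay this aromatic carbon, ortho to a large group, accepts a nitrile-bearing aryl without a change that can be read: cyano in place of hydrogen gives a 1.3-fold higher number from compound 1 to compound 4 (0.10 log units; within the scatter) and so cannot be separated from the unsubstituted phenyl. Going by these compounds alone, the same holds against both earlier neighbours, with a 1.6-fold higher number from compound 3 to compound 4 (0.22 log units; within the scatter) on one side and a 1.6-fold lower number from compound 2 to compound 4 (0.22 log units; within the scatter) on the other, so compound 4 cannot be told apart from any of the three, and the only gap beyond the scatter in the set remains the one between compound 2 and compound 3. The added heavy atom and triple bond of 3-cyanophenyl therefore leave the read-out within the narrow band already seen for these aryl groups, and nothing available accounts for the small differences that do appear in the set.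

The compounds shown carry only phenyl, fluoro-substituted and cyano-substituted aryl groups here, so an aminomethyl group or a carboxylic acid on this aryl remains an open test of whether the position can move the number further. On these data alone, a saturated ring such as morpholine in place of the aryl is equally open, and it would show whether an aromatic ring is needed on this carbon at all.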